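The compounds below may be only part of what the source reports. "The series", "measured", "known", "first", "only" and "open" are said of these compounds alone.

Three compounds on one shared core have numbers in a functional assay on HOS-TE85 cells (Homo sapiens) for inhibition, read by CCK-8 assay, with a stated time of 72 h; a lower number here means a stronger inhibitor, a higher number a weaker inhibitor. Compound 1 `COc1ccc(C)cc1N1C(=O)CSC1c1cccc(C(=O)NCCCCc2ccccc2)c1` gives 300 nM. For compound 2 `CCN(CC)c1ccc(N2C(=O)CSC2c2cccc(C(=O)NCCCCc3ccccc3)c2)cc1` the assay returns only a limit, > 1000 nM. Compound 3 `COc1ccc(F)cc1N1C(=O)CSC1c1cccc(C(=O)NCCCCc2ccccc2)c1` gives 8.8 nM, the lowest number of the three, and both routes to it are large: a 34-fold lower number from compound 1 to compound 3 (1.53 log units; beyond the scatter) and an at least 110-fold lower number from compound 2 to compound 3 (2.05 log units; beyond the scatter).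

Compound 4 `O=C(NCCCCc1ccccc1)c1cccc(C2SCC(=O)N2c2ccccc2)c1` has phenyl in place of 5-fluoro-2-methoxyphenyl on an amide-type nitrogen in a ring. Within the data shown here, no measured compound carries phenyl at this place, so the expectation rests on neighbouring changes. The closest evidence is compound 1, where methyl stands instead of fluoro and the methoxy group stays, since a 34-fold lower number from compound 1 to compound 3 (1.53 log units; beyond the scatter) shows how much that one change moved the number. The move to a different group at the same place also counts, with an at least 3.3-fold higher number from compound 1 to compound 2 (0.52 log units; beyond the scatter). Both of the other groups on this nitrogen give higher numbers than compound 3 does, and compound 4 gives up the whole 5-fluoro-2-methoxyphenyl group. A rise beyond the scatter is therefore expected in this assay, with an estimated step of a 14-fold higher number from compound 3 to compound 4 (1.13 log units; beyond the scatter). Compound 4 is estimated at 120 nM, with an expected range from 20 nM to 700 nM.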

Compound 4, half-maximal inhibitory concentration: 15.9 nM
Compound 4: middle estimate off by 7.5-fold (0.88 log units), on the high side; measured number outside the range, below it.
By their numbers in this assay, from the lowest: compounds 3 and 4 (each within the scatter of the next); then compound 1. At a limit, above all of these: compound 2.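

In this assay, phenyl and 5-fluoro-2-methoxyphenyl on the amide-type nitrogen cannot be told apart, with a 1.8-fold higher number from compound 3 to compound 4 (0.26 log units; within the scatter), so a number of this order does not need the fluoro and methoxy groups on this ring. This changes how the earlier gain from methyl to fluoro reads: phenyl also stands well clear of the 2-methoxy-5-methylphenyl group, with a 19-fold lower number from compound 1 to compound 4 (1.28 log units; beyond the scatter), so compound 1 now looks like a raised number relative to phenyl, and compound 3 no longer looks like a lowered one. Hydrogen in place of diethylamino gives an at least 62-fold lower number from compound 2 to compound 4 (1.79 log units; beyond the scatter), and this step is open-ended, as compound 2 is recorded only as a limit of the assay: the limit of > 1000 nM in this assay, at which 1 of the 4 values shown sits.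

The compounds shown leave open whether methoxy alone or fluoro alone on this phenyl would stay within the scatter of compound 4, and whether methyl alone would account for the higher number of compound 1. They also do not show how a smaller amine such as dimethylamino, or a carboxylic acid, at this phenyl would compare with hydrogen.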